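The source may hold more compounds than are shown below. What is called first, only, known or untested is meant among the compounds shown, and "the series" means these compounds.

Three compounds on the shared core have results in an ADME assay on BHK-21 cells (Mesocricetus auratus) for cytotoxicity, read by MTT assay; on this read-out higher numbers stand for lower toxicity in this test and lower numbers for higher toxicity in this test. Compound 1 `CC(=O)c1ccc2c(c1)nc(-c1ccc(Cl)cc1)n2C1CCCCC1` gives > 100000 nM, which is a limit and not a number. Compound 3 `CC(=O)c1ccc2c(c1)nc(-c1ccccn1)n2C1CCCCC1` gives >= 100000 nM, which is also a limit. For the measured compounds named here, compound 2 `CC(=O)c1ccc2c(c1)nc(-c1ccoc1)n2C1CCCCC1` gives 77000 nM, the only actual number of the three and therefore the sole firm starting point.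

Compound 4 `C/C(=N\NC(N)=S)c1ccc2c(c1)nc(-c1ccoc1)n2C1CCCCC1` keeps compound 2 intact except at the acetyl group: a group of 7 heavy atoms (3 carbon, 3 nitrogen, 1 sulfur; no ring) in place of a group of 3 heavy atoms (2 carbon, 1 oxygen; no ring), on an aromatic carbon.

The measured steps offer only indirect guidance. Two of them, an at least 1.2-fold lower number from compound 1 to compound 2 (0.11 log units; that floor lies within the scatter) and an at least 1.2-fold higher number from compound 2 to compound 3 (0.11 log units; that floor lies within the scatter), have floors that lie within the scatter. The third, a step that the two limits leave unreadable from compound 1 to compound 3, cannot be sized, as the limit of > 100000 nM in this assay, at which 1 of the 3 values shown sits, and the limit of >= 100000 nM in this assay, at which 1 of the 3 values shown sits, show. Going by the values given here, all three exchange a different group and leave the acetyl untouched, so the series holds no measured step for this change.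

With so little to go on, a moderate move towards a lower number in this assay is expected, though a step within the scatter remains possible. The estimate is anchored on compound 2 at 77000 nM, and its range is kept wide. The expected change is a 1.7-fold lower number from compound 2 to compound 4 (0.23 log units; within the scatter). For compound 4 the estimated value is 45000 nM, with an expected range of 12000 nM to 100000 nM.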

Compound 4, half-maximal cytotoxic concentration: > 100000 nM
Compound 4: only a limit was reported; the forecaster's own chance of this, stated with the estimate: 25%; middle value at least 2.2-fold (0.34 log units) from the limit.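

For the compounds shown here, this is the first measured step at this position: on the aromatic carbon, para to a fused ring and meta to the other, replacing acetyl with the group of 7 heavy atoms gives, in this assay, an at least 1.2-fold higher number from compound 2 to compound 4 (0.11 log units; that floor lies within the scatter). Compound 4 gives > 100000 nM, which is a limit and not a number. The exchange therefore did not bring the number down in this test, even with a larger group carrying hydrogen-bond donors that acetyl lacks, although the step's floor alone does not separate the change from the scatter, and limits now make up most of the values shown: the limit of > 100000 nM in this assay, at which 2 of the 4 values shown sit.

Going by these compounds, the true size of the step remains unknown, as does whether the same exchange would read alike with 4-chlorophenyl or pyridin-2-yl in place of furan-3-yl on the shared core. The compounds shown also leave open how a smaller group at this aromatic carbon, such as a primary amine or a carboxylic acid, would read in this assay.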